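Pyrrolidine amide replacing cyclopropyl amide in a thiourea series

The compounds below may be only part of what the source reports. "The series", "measured", "known", "first", "only" and "open" are said of these compounds alone.

Three diaryl ether thioureas have been tested in a functional assay on PC-3 cells (Homo sapiens) for cytotoxicity, read by MTT assay, with a stated time of 48 h; on this read-out higher numbers stand for weaker inhibition and lower numbers for stronger inhibition. Compound 1 `O=C(NCc1ccccc1)c1cc(Oc2cccc(NC(=S)Nc3ccc(Cl)cc3)c2)ccn1` gives 15800 nM, compound 2 `CNC(=O)c1cc(Oc2cccc(NC(=S)Nc3ccc(F)c(F)c3)c2)ccn1` gives 33100 nM, and compound 3 `O=C(NC1CC1)c1cc(Oc2cccc(NC(=S)Nc3cccc(C(F)(F)F)c3)c2)ccn1` gives 22100 nM. Compound 3 sits between the other two, with its gap to compound 1 and its gap to compound 2 both within the scatter, so the three cannot be ordered. Compound 4 `O=C(c1cc(Oc2cccc(NC(=S)Nc3cccc(C(F)(F)F)c3)c2)ccn1)N1CCCC1` is the next member: pyrrolidin-1-yl in place of cyclopropylamino on a carbonyl carbon. Within the data shown here, no step between measured compounds bears on this change, so a step of no real size is expected for compound 4, within the scatter in either direction, giving a 1.1-fold higher number from compound 3 to compound 4 (0.05 log units; within the scatter). Compound 4 is therefore estimated at 25000 nM in this assay, with a range from 10000 nM to 60000 nM.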

Compound 4, half-maximal inhibitory concentration: 27000 nM
Compound 4: middle estimate off by 1.1-fold (0.03 log units), on the low side, and the stated range covers the measured number.
By their numbers in this assay, from the lowest: compounds 1, 3, 4 and 2 (each within the scatter of the next, the first and the last beyond it).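

In this assay, among these compounds, the one comparison at this position gives a 1.2-fold higher number from compound 3 to compound 4 (0.09 log units; within the scatter), which lies within the scatter, for pyrrolidin-1-yl in place of cyclopropylamino on a carbonyl carbon. The carbonyl substituent can therefore lose the hydrogen-bond donor counted on cyclopropylamino, and gain a ring atom, without a resolvable shift on these cells. No measurement here offers an explanation for this result.

As far as these compounds go, whether morpholin-4-yl or an open-chain dimethylamino group on this carbonyl carbon would also stay within the scatter remains open. So does whether the same replacement holds alongside other substituents on the thiourea.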